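This account rests on a few compounds, and the source may have more. Where it says the series, first, only, none or still open, it means among the compounds named here.

Measured so far in a functional assay on CHO-K1 cells for antagonist activity at adenosine receptor A1 (Homo sapiens), read by a beta-galactosidase reporter and cAMP accumulation, with stated times of 15 min and 6 h; on this read-out lower numbers stand for stronger inhibition and higher numbers for weaker inhibition:
Compound 1 `Cc1ccc(-c2nc(N)c3ccsc3n2)o1`: 493 nM
Compound 2 `Cc1ccc(-c2nc(N)c3cc(Cc4ccccc4Cl)sc3n2)o1`: 26.1 nM
Compound 3 `CC(C)c1ccc(-c2nc(N)c3cc(Cc4ccccc4)sc3n2)o1`: 283 nM

Compound 3 stands second highest of the three numbers. Its nearest neighbour is compound 1, whose value of 493 nM lies within the scatter of compound 3 at 283 nM; compound 2, at 26.1 nM, sits far lower. Among the compounds with values here, the only single-site step measured, a 19-fold lower number from compound 1 to compound 2 (1.28 log units; beyond the scatter), concerns the 2-chlorobenzyl group and leaves the aryl ring untouched. Compound 4 `Cc1nc(-c2nc(N)c3cc(Cc4ccccc4)sc3n2)cs1` differs from compound 3 in one place: 2-methyl-1,3-thiazol-4-yl in place of 5-isopropylfuran-2-yl on an aromatic carbon. Within the data shown here, no measured step bears on this exchange. Compound 1 and compound 3 differ in two places, and their values show only that the two furan variants land within the scatter of each other. With no guide for the aryl exchange, the expected step is a 1.2-fold higher number from compound 3 to compound 4 (0.09 log units; within the scatter), which is none beyond the scatter, with a wide range on either side. Compound 4 is therefore estimated at 350 nM, with a range from 90 nM to 1400 nM.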

Compound 4, inhibition constant: 263 nM
For compound 4 the middle estimate is 1.3-fold (0.12 log units) above the measured one; the range from low to high includes it.
By their numbers in this assay, from the lowest: compound 2; then compounds 4, 3 and 1 (each within the scatter of the next).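

In this assay, 2-methyl-1,3-thiazol-4-yl in place of 5-isopropylfuran-2-yl on the aromatic carbon between two ring nitrogen atoms gives a 1.1-fold lower number from compound 3 to compound 4 (0.03 log units; within the scatter). Within the data shown here, this is the first step measured at this position, and it shows that, with the benzyl group held constant, the exchange leaves the read-out within the scatter, although a five-membered aromatic ring with 1 hetero atom leaves and one with 2 hetero atoms enters. Nothing measured here indicates why the two groups read alike.

The compounds shown leave open whether the same exchange would also stay within the scatter with the 2-chlorobenzyl group of compound 2 in place of the benzyl group. Also open, from the compounds shown here alone, is how this position would respond to something other than a five-membered aromatic ring, such as a phenyl ring or a morpholine.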